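The source may hold more compounds than are shown below. What is called first, only, known or untested is meant among the compounds shown, and "the series" means these compounds.

Compound 1 `NCCCC[C@H](NC(=O)CN(c1nc(Cl)nc2[nH]cnc12)C1CC1)C(=O)OCc1ccccc1` gives 26.1% in a functional assay on the whole organism (Tail, strain ICR) with Mus musculus as the target, in the tail flick test, with a stated time of 30 min, at a dose of 25 umol/kg by the oral route; on this read-out higher numbers stand for a stronger effect at the one dose given and lower numbers for a weaker effect.
Compound 2 `O=C(CN(c1nc(Cl)nc2[nH]cnc12)C1CC1)N[C@@H](CCC(=O)OCc1ccccc1)C(=O)OCc1ccccc1` gives 52.8%.
Compound 3 `CSCC[C@H](NC(=O)CN(c1nc(Cl)nc2[nH]cnc12)C1CC1)C(=O)O` gives 20.4%.

Among these three, compound 2 stands highest: its nearest neighbour is compound 1, and the gap to compound 3 is wider still, both gaps beyond the scatter. Compound 4 `NC(=O)CC[C@H](NC(=O)CN(c1nc(Cl)nc2[nH]cnc12)C1CC1)C(=O)OCc1ccccc1` keeps the shared core and the amide-linked side chain of compound 2 but carries a different end group: amino in place of benzyloxy on a carbonyl carbon, which reads, cut one bond further out, as benzyloxycarbonyl to carbamoyl.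

Among the measured compounds shown here, only one measured step bears on this change. The step of a number 26.7 percentage points higher from compound 1 to compound 2 (beyond the scatter) shows that putting a benzyloxycarbonyl end on the side chain raised the effect by a modest amount. Compound 4 removes the benzyloxy part of that very group and puts an amino in its place, so the expectation is a step in the opposite direction, of roughly similar size: a number 22.8 percentage points lower from compound 2 to compound 4 (beyond the scatter) is expected. Compound 3, with a free acid end, sits low, which fits the same reading. Compound 4 is therefore estimated at 30%, within a range from 15% to 48%.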

Compound 4, a percentage reported as activity, at one dose (the size of the read-out at that dose, not a potency): 30.8%
The estimate for compound 4 lay 0.8 percentage points below the measured number, within the range that was stated.
By their numbers in this assay, from the lowest: compounds 3, 1 and 4 (each within the scatter of the next, the first and the last beyond it); then compound 2.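

In this assay, amino in place of benzyloxy on this carbonyl carbon gives a number 22 percentage points lower from compound 2 to compound 4 (beyond the scatter), so the higher number of compound 2 does not survive this exchange at the end of the chain. Carbamoyl in place of 2-aminoethyl gives a number 4.7 percentage points higher from compound 1 to compound 4 (within the scatter), so this assay does not separate these two chain ends, and benzyloxycarbonyl is the only one of the three ends that stands apart. Nothing measured here explains why the benzyloxy group makes this difference.

The compounds shown leave open whether the benzene ring of the benzyloxy group is what counts, or whether a smaller group on the same carbonyl carbon, such as methoxy or hydroxy, would keep the effect. A longer chain carrying the benzyloxycarbonyl end is also an open case.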